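Replacing the Hydroxy of Compound 2 with Amino

The compounds below may be only part of what the source reports. "The series", "measured", "known", "first", "only" and "open" are said of these compounds alone.

Measured in a functional assay on A-431 cells (Homo sapiens) for cytotoxicity, read by trypan blue exclusion, with a stated time of 96 h; a higher number here means a weaker inhibitor of growth, a lower number a stronger inhibitor of growth:
Compound 1 `COc1ccc(NS(=O)(=O)/C=C/c2c(OC)cc(OC)cc2OC)cc1`: 30 nM
Compound 2 `COc1cc(OC)c(/C=C/S(=O)(=O)Nc2ccc(OC)c(O)c2)c(OC)c1`: 600 nM

Of these two numbers, compound 2 has the higher, so it is the weaker inhibitor of growth. Within the data shown here, only one measured step bears on what comes next, hydroxy in place of hydrogen on an aromatic carbon: a 20-fold higher number from compound 1 to compound 2 (1.30 log units; beyond the scatter). Compound 3 `COc1cc(OC)c(/C=C/S(=O)(=O)Nc2ccc(OC)c(N)c2)c(OC)c1` alters that same hydroxy: amino in place of hydroxy on an aromatic carbon. This is amino in place of hydroxy on an aromatic carbon, ortho to a methoxy group. Among the measured compounds shown here, no compound with an amino group has yet been measured, so the size of the change remains uncertain. Compound 1 and its step to compound 2 show only what adding the hydroxy did, and on that basis a fall in this assay is expected, probably recovering part of that large rise. The expected step is a 6.7-fold lower number from compound 2 to compound 3 (0.82 log units; beyond the scatter). Compound 3 is estimated at 90 nM, with an expected range of 15 nM to 500 nM.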

Compound 3, concentration for 50% growth inhibition: 5 nM
Beside the measured number, compound 3's estimate is 18-fold (1.26 log units) above it; the whole stated range lies above it.
By their numbers in this assay, from the lowest: compound 3; then compound 1; then compound 2.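

In this assay the change from 3-hydroxy-4-methoxyphenyl to 3-amino-4-methoxyphenyl gives a 120-fold lower number from compound 2 to compound 3 (2.08 log units; beyond the scatter), so this position, ortho to a methoxy group, separates sharply two groups with the same counts of hydrogen-bond donors and acceptors and no net charge. Substitution here is therefore not harmful in itself: amino in place of hydrogen gives a 6.0-fold lower number from compound 1 to compound 3 (0.78 log units; beyond the scatter), while hydroxy in place of hydrogen gave a 20-fold higher number from compound 1 to compound 2 (1.30 log units; beyond the scatter), so the direction of the step depends on the group. Nothing measured here accounts for the difference between these two groups.

On these data alone, how a methylamino, a dimethylamino or an acetamido group would compare at this position remains open. All three values come from this assay, so whether the same order holds on other cells is also unknown.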